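A few compounds are considered here, and "the series" means these few. Any claim that something is new, unique, unknown or untested is made for them only; others in the source may bear on it.

Measured so far in a functional assay on microsomes from liver (Rattus norvegicus, strain Wistar) for inhibition, read by spectrophotometry, with a stated time of 60 min; a higher number here means a weaker inhibitor, a lower number a stronger inhibitor:
- compound 1 `COc1cc(C2CC(=NOC(=O)c3ccc(Cl)cc3)CC(c3ccc(O)c(OC)c3)N2C)ccc1O` gives 121000 nM
- compound 2 `COc1ccc(C(=O)ON=C2CC(c3ccc(O)c(OC)c3)N(C)C(c3ccc(O)c(OC)c3)C2)c(OC)c1` gives 52000 nM
- compound 3 `COc1cc(C2CC(=NOC(=O)c3ccc([N+](=O)[O-])cc3)CC(c3ccc(O)c(OC)c3)N2C)ccc1O` gives 82000 nM

Compound 3 lies within the scatter of both compound 1 and compound 2. Compound 4 `COc1cc(C2CC(=NOC(=O)c3ccc(Br)cc3)CC(c3ccc(O)c(OC)c3)N2C)ccc1O` has bromo in place of nitro on an aromatic carbon. For the measured compounds named here, no measured compound carries bromo, so the closest guide is the exchange of chloro for nitro at that place (a 1.5-fold lower number from compound 1 to compound 3 (0.17 log units; within the scatter)), which stayed within the scatter. Replacing the 2,4-dimethoxyphenyl with 4-nitrophenyl (a 1.6-fold higher number from compound 2 to compound 3 (0.20 log units; within the scatter)) also stayed within it. No step beyond the scatter is therefore expected in this assay for this change. The expected step is small (a 1.2-fold higher number from compound 3 to compound 4 (0.09 log units; within the scatter)). The estimated value for compound 4 is 100000 nM within an expected range (50000 nM to 200000 nM).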

Compound 4, half-maximal inhibitory concentration: 112000 nM
Compound 4: the middle estimate sits 1.1-fold (0.05 log units) below what was measured; the measured number falls inside the stated range.
By their numbers in this assay, from the lowest: compounds 2, 3, 4 and 1 (each within the scatter of the next, the first and the last beyond it).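

In this assay, bromo on this aromatic carbon reads much like the other single groups tried there, nitro (a 1.4-fold higher number from compound 3 to compound 4 (0.14 log units; within the scatter)) and chloro (a 1.1-fold lower number from compound 1 to compound 4 (0.03 log units; within the scatter)), with both steps within the scatter. Against the 2,4-dimethoxyphenyl of compound 2, the 4-bromophenyl shows a modest gap beyond the scatter (a 2.2-fold higher number from compound 2 to compound 4 (0.33 log units; beyond the scatter)), as the 4-chlorophenyl of compound 1 did. Nothing available explains these differences.

Still open, going by these compounds, is whether an amine or a carboxylic acid at this place would move the number beyond the scatter. On these data alone, it is also open whether a single methoxy group would match the two in compound 2.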